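The compounds below may be only part of what the source reports. "The series", "measured", "known", "first", "only" and "open" are said of these compounds alone.

Measured compounds:
- Compound 1, `O=S(=O)(Nc1ccc2oc(-c3ccccc3)nc2c1)c1ccc(Cl)cc1`: in an assay on cells for inhibition of HSP60/HSP10 (Homo sapiens), with a stated time of 60 min (a higher number here means a weaker inhibitor, a lower number a stronger inhibitor), compound 1 gives > 100000 nM, which is a limit of the assay and not a number.
- Compound 2, `COc1ccc(S(=O)(=O)Nc2ccc3oc(-c4ccccc4)nc3c2)cc1`: in this assay compound 2 gives > 100000 nM, likewise a limit of the assay.

Among the compounds with values here, compound 2 thus stands at the assay limit, the same point as the only other measured compound, and its place on the numbers is known only as that limit. Within the data shown here, the single measured step, a step that the two limits leave unreadable from compound 1 to compound 2, cannot be sized or given a direction because both of its ends sit at the limit of > 100000 nM in this assay, at which 2 of the 2 values shown sit.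

Compound 3, `O=S(=O)(Nc1ccc2oc(-c3ccccc3)nc2c1)c1ccc(O)cc1`, is the next member, derived from compound 2 by hydrogen in place of methyl on an oxygen on an aromatic ring. Among the measured compounds shown here, no measured step covers this change; the one step in hand concerns a different ring and is itself unreadable, so nothing indicates movement away from the limit. The step expected in this assay for compound 3 is therefore estimated as a step that the limit leaves unreadable from compound 2 to compound 3, that is, no change beyond the scatter. Compound 3 is expected in this assay to come out near 150000 nM, with a range of 30000 nM to 1000000 nM, and most probably reported again only as a limit.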

Compound 3, half-maximal inhibitory concentration: 88000 nM
Compound 3: middle estimate off by 1.7-fold (0.23 log units), on the high side; low and high end bracket the measured number.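

At the position carrying the 4-methoxyphenyl group in compound 2, the 4-hydroxyphenyl group gives the first result in this assay that is a number and not a limit: compound 3 gives 88000 nM. Hydrogen in place of methyl on the oxygen gives an at least 1.1-fold lower number from compound 2 to compound 3 (0.05 log units; that floor lies within the scatter), and the change from chloro to hydroxy gives an at least 1.1-fold lower number from compound 1 to compound 3 (0.05 log units; that floor lies within the scatter). Each of these steps is only a floor that lies within the scatter, and the real size of either stays unknown, because the other two compounds sit at a limit: the limit of > 100000 nM in this assay, at which 2 of the 3 values shown sit.

On these data alone, the step from chloro to methoxy still cannot be read, and whether an amine or a carboxylic acid in place of the hydroxy would give a number further from the limit stays open. Equally open, as far as these compounds go, is how far the value would move with changes elsewhere on the shared core, which is the same in compound 1, compound 2 and compound 3.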